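Working notes: from phenyl to 3,4-dimethylphenyl

A few compounds are considered here, and "the series" means these few. Any claim that something is new, unique, unknown or untested is made for them only; others in the source may bear on it.

The series shares one core and varies the aryl group on the carbonyl carbon. In a functional assay on HepG2 cells (Homo sapiens) for antiproliferative activity, read by MTT assay, with a stated time of 48 h (on this read-out higher numbers stand for weaker inhibition and lower numbers for stronger inhibition), compound 1 (`COc1ccc(/C=C/c2cc(OC)cc(OC)c2/C=C/C(=O)c2cccc(Cl)c2)cc1`) gives 9.5 ug/mL, compound 2 (`COc1ccc(/C=C/c2cc(OC)cc(OC)c2/C=C/C(=O)c2ccc(Br)cc2)cc1`) gives 12.9 ug/mL and compound 3 (`COc1ccc(/C=C/c2cc(OC)cc(OC)c2/C=C/C(=O)c2ccccc2)cc1`) gives 6.8 ug/mL. Compound 3 carries the unsubstituted phenyl, and its value cannot be separated from either of the other two.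

Compound 4 (`COc1ccc(/C=C/c2cc(OC)cc(OC)c2/C=C/C(=O)c2ccc(C)c(C)c2)cc1`) has 3,4-dimethylphenyl in place of phenyl on a carbonyl carbon.

Within the data shown here, two measured steps bear most directly on this change, both replacing a halogen on the ring with hydrogen: a 1.4-fold lower number from compound 1 to compound 3 (0.15 log units; within the scatter) and a 1.9-fold lower number from compound 2 to compound 3 (0.28 log units; within the scatter). A third, a 1.4-fold higher number from compound 1 to compound 2 (0.13 log units; within the scatter), compares the two halogenated rings. All three are small, so the aryl group has not yet produced a clear change in this series. Among the measured compounds shown here, no measured compound carries methyl groups on this ring, so the evidence is indirect. Both substituted rings give numbers on the higher side of compound 3, so a slight move in that direction is expected, but nothing beyond the scatter. The expected step is a 1.3-fold higher number from compound 3 to compound 4 (0.12 log units; within the scatter). For compound 4 the estimated value is 9 ug/mL, with an expected range from 4.5 ug/mL to 18 ug/mL.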

Compound 4, half-maximal inhibitory concentration: 0.2 ug/mL
Compound 4: middle estimate off by 45-fold (1.65 log units), on the high side; measured number outside the range, below it.
By their numbers in this assay, from the lowest: compound 4; then compounds 3, 1 and 2 (each within the scatter of the next).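

The aryl group on the carbonyl carbon is not a silent position. In this assay, 3,4-dimethylphenyl in place of phenyl gives a 34-fold lower number from compound 3 to compound 4 (1.53 log units; beyond the scatter), whereas every step among the phenyl and halogenated rings stayed within the scatter. The change is just as clear against the halogenated rings, with a 48-fold lower number from compound 1 to compound 4 (1.68 log units; beyond the scatter) and a 65-fold lower number from compound 2 to compound 4 (1.81 log units; beyond the scatter), so compound 4 is the most potent of the four and the only one separated from the rest. Nothing available gives a reason for a step of this size.

Among these compounds, with only one methylated ring, it remains open whether the result needs both methyl groups or whether a single methyl group would give much of the same step. As far as these compounds go, it is equally open whether the step is particular to methyl or would also appear with other groups on this ring, such as an ethyl group, a methoxy group or an amine.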